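The compounds below may be only part of what the source reports. "The series", "measured", "known", "first", "only" and "open" are said of these compounds alone.

In a functional assay on OCI-Ly10 cells (Homo sapiens) for cytotoxicity, read by CCK-8 assay, with a stated time of 72 h (a higher number here means a weaker inhibitor, a lower number a stronger inhibitor), compound 2 `CCn1cc(NC(=O)c2cnc3ccc(N[C@@H]4CCCNC4)nn23)c(C(F)(F)F)n1` gives 3600 nM and compound 1 `Cn1cc(NC(=O)c2cnc3ccc(N[C@@H]4CCCNC4)nn23)c(C(F)(F)F)n1` gives 2800 nM, two values within the usual scatter of each other. Compound 3 `O=C(Nc1cn(C2CCOCC2)nc1C(F)(F)F)c1cnc2ccc(N[C@@H]3CCCNC3)nn12` carries oxan-4-yl in place of ethyl on an aromatic nitrogen. Among the compounds with values here, the one measured step at that aromatic nitrogen is a 1.3-fold higher number from compound 1 to compound 2 (0.11 log units; within the scatter), which stays within the scatter. That step adds far less than oxan-4-yl does, so it is only a thin guide, and no change beyond the scatter is expected. The expected step is a 1.2-fold lower number from compound 2 to compound 3 (0.08 log units; within the scatter). Compound 3 is estimated at 3000 nM, with a range of 1200 nM to 7000 nM.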

Compound 3, half-maximal inhibitory concentration: 10500 nM
Beside the measured number, compound 3's estimate is 3.5-fold (0.54 log units) below it; measured number outside the range, above it.
By their numbers in this assay, from the lowest: compounds 1 and 2 (each within the scatter of the next); then compound 3.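

Replacing either small alkyl group on this aromatic nitrogen with oxan-4-yl clearly shifts the number in this assay, with a 2.9-fold higher number from compound 2 to compound 3 (0.46 log units; beyond the scatter) and a 3.8-fold higher number from compound 1 to compound 3 (0.57 log units; beyond the scatter). Unlike the earlier change from methyl to ethyl, both steps lie beyond the scatter, so this position does respond to what it carries, and here the change gives a weaker inhibitor. Nothing available explains this loss.

From the compounds shown here alone, whether the loss follows the ring or its oxygen remains open. Cyclohexyl, the same ring with carbon in place of that oxygen, would separate the two, while a longer chain such as propyl would fill the gap between ethyl and oxan-4-yl.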